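A few compounds are considered here, and "the series" means these few. Any claim that something is new, unique, unknown or untested is made for them only; others in the source may bear on it.

Series notes. In an assay on HEK293 cells for inhibition of N-acylethanolamine-hydrolyzing acid amidase (Rattus norvegicus), read by LC-MS, with a stated time of 30 min (on this read-out lower numbers stand for stronger inhibition and higher numbers for weaker inhibition), compound 1 `Cc1ccc(-c2ccc(CCC(=O)N3CCCC3)cc2)cc1` gives 33200 nM and compound 2 `O=C(CCc1ccc(-c2ccccc2F)cc1)N1CCCC1` gives 2800 nM. Compound 3 `O=C(CCc1ccc(-c2ccccn2)cc1)N1CCCC1` reaches only the limit of this assay, > 100000 nM, as recorded in the limit of > 100000 nM in this assay, at which 1 of the 3 values shown sits. The measured steps leading to it are an at least 3.0-fold higher number from compound 1 to compound 3 (0.47 log units; beyond the scatter) and an at least 35-fold higher number from compound 2 to compound 3 (1.55 log units; beyond the scatter), so compound 3 stands weakest of the three on the numbers shown, without a number of its own. Compound 4 `O=C(CCc1ccc(-c2cccs2)cc1)N1CCCC1` differs from compound 3 by thiophen-2-yl in place of pyridin-2-yl on an aromatic carbon. Both measured steps toward compound 3 run toward the pyridin-2-yl group and lie beyond the scatter; the step away from that group is therefore expected to give a lower number in this assay, although its size is not fixed by those two steps. Compound 4 is estimated at 12000 nM, between 2000 nM and 100000 nM. The expected step is an at least 8.3-fold lower number from compound 3 to compound 4 (0.92 log units; beyond the scatter).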

Compound 4, half-maximal inhibitory concentration: > 100000 nM
Compound 4: only a limit was reported (the forecaster's own chance of this, stated with the estimate: 25%); middle value at least 8.3-fold (0.92 log units) away from the limit.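

Compound 4 joins compound 3 at the limit of the assay, so a second heteroaromatic group on this aromatic carbon, now a five-membered ring with sulfur, also gives no number of its own in this assay. Against the two substituted phenyl groups, the change gives an at least 35-fold higher number from compound 2 to compound 4 (1.55 log units; beyond the scatter) and an at least 3.0-fold higher number from compound 1 to compound 4 (0.47 log units; beyond the scatter). The step between compound 3 and compound 4 cannot be read, because both values are limits: the limit of > 100000 nM in this assay, at which 2 of the 4 values shown sit.

Whether the ring hetero atom itself accounts for the loss stays open. An unsubstituted phenyl group at this place would test that, and a fluorine on the thiophen-2-yl ring would test whether a measurable number returns.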